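The source may report more compounds than this note shows. Statements on the series, on what has been measured and on what is new or still open speak of the compounds shown alone.

Three compounds have been measured in a functional assay on Jurkat cells (Homo sapiens) for inhibition, read by MTT assay, with a stated time of 24 h (on this read-out higher numbers stand for weaker inhibition and lower numbers for stronger inhibition), so far:

- compound 1 `Cc1ccc(CNc2cc(C(F)(F)F)cc3[nH]ncc23)c([N+](=O)O)c1` gives 7250 nM
- compound 2 `O=[N+]([O-])c1ccc(Cl)cc1CNc1cc(C(F)(F)F)cc2[nH]ncc12` gives 1100 nM
- compound 3 `O=[N+](O)c1c(Cl)cccc1CNc1cc(C(F)(F)F)cc2[nH]ncc12` gives > 20000 nM as a limit of the assay, not a number

Of the two true numbers, compound 1 holds the higher, so it is the weaker inhibitor of that pair, and compound 2 lies below it by more than the usual scatter. Compound 4 `CS(=O)(=O)c1ccc(CNc2cc(C(F)(F)F)cc3[nH]ncc23)c([N+](=O)O)c1` has not yet been measured. It replaces the methyl of compound 1 with methylsulfonyl on an aromatic carbon, para to a large group (methylsulfonyl in place of methyl on an aromatic carbon). Going by the values given here, no measured pair differs in one place only, so the expectation in this assay is tentative: no step beyond the scatter, and no firm direction. For compound 4 the estimated value is 6000 nM in an expected range from 1800 nM to 20000 nM as its ends. This estimate means an expected 1.2-fold lower number from compound 1 to compound 4 (0.08 log units; within the scatter) and awaits measurement.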

Compound 4, half-maximal inhibitory concentration: > 20000 nM
Compound 4: no number, only a limit; the forecaster's own chance of this, stated with the estimate: 15%; at least 3.3-fold (0.52 log units) between middle value and limit.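

The methyl of compound 1 does not tolerate every replacement: in this assay, methylsulfonyl in its place on the aromatic carbon gives an at least 2.7-fold higher number from compound 1 to compound 4 (0.44 log units; beyond the scatter). Compound 4 gives > 20000 nM, which is a limit of the assay and not a number. This is the first change in a single place among the compounds shown, and its full size cannot be read, because the step ends on a limit: the limit of > 20000 nM in this assay, at which 2 of the 4 values shown sit.

Only this one replacement of the methyl is shown, so it remains open whether the weaker inhibition is particular to methylsulfonyl. An amine, a methoxy group or a carboxylic acid on the same aromatic carbon might stay close to compound 1 or might also reach the limit, and the compounds shown do not tell which.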